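The source may hold more compounds than are shown below. What is called first, only, known or untested is meant among the compounds shown, and "the series" means these compounds.

Working notes on the series, followed in an ADME assay on HUVEC cells (Homo sapiens) for antiproliferative activity, read by MTT assay, with a stated time of 48 h; on this read-out lower numbers stand for stronger inhibition and higher numbers for weaker inhibition.

Compound 1 `N#CC1=C(N)Oc2c(c3nc4ccccc4nc3c3ccccc23)C12C(=O)N(Cc1cnnn1-c1ccc([N+](=O)[O-])cc1)c1ccccc12` bears a 4-nitrophenyl on an aromatic nitrogen. In this assay compound 1 reaches only the limit of > 50000 nM. Compound 2 `Cc1ccc(-n2nncc2CN2C(=O)C3(C(C#N)=C(N)Oc4c3c3nc5ccccc5nc3c3ccccc43)c3ccccc32)cc1C` differs from compound 1 in a single place: 3,4-dimethylphenyl in place of 4-nitrophenyl on an aromatic nitrogen. In this assay compound 2 likewise stops at the limit of > 50000 nM. The step that the two limits leave unreadable from compound 1 to compound 2 is therefore not readable, since both ends rest on the same limit, which is what the limit of > 50000 nM in this assay, at which 3 of the 3 values shown sit, records.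

Compound 3 `N#CC1=C(N)Oc2c(N)cc3nc4ccccc4nc3c2C12C(=O)N(Cc1cnnn1-c1ccc([N+](=O)[O-])cc1)c1ccccc12` is built on another core; the difference between the core of compound 3 and the core of compound 1 is not broken down here. In this assay compound 3 also returns the limit of > 50000 nM.

Compound 4 `Cc1ccc(-n2nncc2CN2C(=O)C3(C(C#N)=C(N)Oc4c(N)cc5nc6ccccc6nc5c43)c3ccccc32)cc1C` has not yet been measured. It stands to compound 3 as compound 2 stands to compound 1, the change being 3,4-dimethylphenyl in place of 4-nitrophenyl on an aromatic nitrogen at the same place. Going by the values given here, the one precedent for this change, from compound 1 to compound 2, gives no readable size, and the whole set so far is described by the limit of > 50000 nM in this assay, at which 3 of the 3 values shown sit.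

Among the compounds with values here, compound 4 is expected to give 60000 nM because the limit of > 50000 nM in this assay, at which 3 of the 3 values shown sit, leaves no member of the series with a measurable number. Compound 4 is estimated to lie between 25000 nM and 150000 nM. The expected step that the limit leaves unreadable from compound 3 to compound 4 is thus essentially flat and most likely will again be reported only as a limit.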

Compound 4, half-maximal inhibitory concentration: > 50000 nM
Compound 4 was reported as a limit; the forecaster's own chance of this, stated with the estimate: 85%; the middle value lies beyond the limit too.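

In this assay compound 4 returns > 50000 nM, which is a limit and not a number. No step can be read from compound 3 to compound 4, since both ends rest on the same limit: the limit of > 50000 nM in this assay, at which 4 of the 4 values shown sit.

The compounds shown leave open whether either the aryl group on the aromatic nitrogen or the core has any effect on the read-out.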